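Writhing inhibition: pyridin-2-yl in place of 3-methylphenyl

This account rests on a few compounds, and the source may have more. Where it says the series, first, only, none or still open, it means among the compounds named here.

Compound 1, `Cc1ccc(-c2cc(C)n(S(=O)(=O)Oc3ccccc3)n2)cc1`: 50.7%
Compound 2, `Cc1ccc(-c2cc(C)n(S(=O)(=O)Oc3ccc(I)cc3)n2)cc1`: 17.2%
Compound 3, `Cc1cccc(-c2cc(C)n(S(=O)(=O)Oc3ccccc3)n2)c1`: 43.8%

In a functional assay on the whole organism for inhibition, with Mus musculus as the target, in the writhing test, with stated times of 3 days and 20 min, at a dose of 30 mg/kg by the oral route (on this read-out lower numbers stand for less inhibition and higher numbers for more inhibition at the one dose given (going by the name of the read-out)), compound 3 stands second of the three numbers; against compound 1 the gap is a number 6.9 percentage points lower from compound 1 to compound 3 (within the scatter), while compound 2 lies well apart, as a number 33.5 percentage points lower from compound 1 to compound 2 (beyond the scatter) shows. Compound 4, `Cc1cc(-c2ccccn2)nn1S(=O)(=O)Oc1ccccc1`, is not yet measured; it differs from compound 3 in pyridin-2-yl in place of 3-methylphenyl on an aromatic carbon. Among the measured compounds shown here, the only measured step at this position is the one from compound 1 to compound 3, which stayed within the scatter; the step from compound 1 to compound 2 concerns another ring and does not bear directly. For the measured compounds named here, no step introduces a ring nitrogen, so the expectation for compound 4 is uncertain, and a step of about a number 5.8 percentage points lower from compound 3 to compound 4 (within the scatter) is estimated. Compound 4 is thus expected to give roughly 38%, between 15% and 60%.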

Compound 4, a percentage reported as inhibition, in the whole organism at one dose (the size of the read-out at that dose, not a potency): 15%
Compound 4: the middle estimate sits 23 percentage points above what was measured; the measured number falls inside the stated range.
By their numbers in this assay, from the lowest: compounds 4 and 2 (each within the scatter of the next); then compounds 3 and 1 (each within the scatter of the next).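

In this assay this aromatic carbon of the five-membered ring proves sensitive to the ring it carries: a number 28.8 percentage points lower from compound 3 to compound 4 (beyond the scatter), and a number 35.7 percentage points lower from compound 1 to compound 4 (beyond the scatter). The two methylphenyl groups stay within the scatter of each other, so the ring swap matters here where the methyl placement did not. Nothing available explains this loss.

Still open, as far as these compounds go, is whether the loss follows the ring nitrogen or the missing methyl. Unsubstituted phenyl or pyridin-3-yl on this carbon would help separate the two.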